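The source may hold more compounds than are shown below. What is called first, only, known or untested is meant among the compounds shown, and "the series" means these compounds.

Measured so far in a functional assay on Shh Light II cells (Mus musculus) for inhibition, read by a luciferase reporter; a lower number here means a stronger inhibitor, a higher number a weaker inhibitor:
compound 1 `Cc1ccccc1NC(=O)N1CCC(c2nc(-c3ccc4ccccc4n3)no2)CC1` — 440 nM
compound 2 `O=C(NC1CCCCC1)N1CCN(c2nc(-c3ccc4ccccc4n3)no2)CC1` — 53 nM
compound 3 `COc1ccccc1NC(=O)N1CCC(c2noc(-c3ccc4ccccc4n3)n2)CC1` — 2400 nM

Compound 1 sits second highest of the three numbers: compound 3 gives the higher number, compound 2 the lower one, and both gaps lie beyond the scatter. The next compound is compound 4 `O=C(NC1CCCCC1)N1CCC(c2nc(-c3ccc4ccccc4n3)no2)CC1`, which differs from compound 1 in one place (cyclohexyl in place of 2-methylphenyl on an amide-type nitrogen). Going by the values given here, no measured pair shows this same change, so the size of the step is open. Compound 2, which also carries cyclohexylcarbamoyl, gives 53 nM, the lowest number of the three, but its core differs as well, so that reading is only a hint. A moderate downward step beyond the scatter is expected, a 3.7-fold lower number from compound 1 to compound 4 (0.56 log units; beyond the scatter). For compound 4 in this assay the estimate is 120 nM, within a range of 40 nM to 350 nM.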

Compound 4, half-maximal inhibitory concentration: 57 nM
Compound 4: middle estimate off by 2.1-fold (0.32 log units), on the high side; measured number inside the range.
By their numbers in this assay, from the lowest: compounds 2 and 4 (each within the scatter of the next); then compound 1; then compound 3.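

In this assay, going by these compounds alone, cyclohexyl in place of 2-methylphenyl on an amide-type nitrogen gives a 7.7-fold lower number from compound 1 to compound 4 (0.89 log units; beyond the scatter) with the rest of the structure unchanged, the first direct reading of this position. In this pair, then, an aromatic ring on that nitrogen is not required for a low number, and the non-aromatic ring gives the stronger inhibitor. No measurement at hand accounts for the step.

Open, as far as these compounds go, is how cyclopentyl, unsubstituted phenyl or an open chain such as n-butyl would read on that nitrogen. Also open, from the compounds shown here alone, is whether the same change carries over to the core of compound 3.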